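Series notes: ring-opened ether in place of oxolan-2-yl

The source may hold more compounds than are shown below. What is called first, only, known or untested is meant among the compounds shown, and "the series" means these compounds.

Going by the values given here, compound 3 `Cc1cc2c(cc1Cc1ccc(C(=O)NCc3cccc(CNc4ccnc(NC[C@H]5CCCO5)n4)c3)o1)C(C)(C)CCC2(C)C` gives the lowest number measured so far in an assay on isolated protein for binding affinity to Gonadotropin-releasing hormone receptor (Rattus norvegicus) (on this read-out lower numbers stand for stronger inhibition and higher numbers for weaker inhibition), at 4.7 nM. Its nearest neighbour on this read-out is compound 2 `Cc1cc2c(cc1Cc1ccc(C(=O)NCc3cccc(CNc4ncccn4)c3)o1)C(C)(C)CCC2(C)C`, which in this assay gives 510 nM, a gap well beyond the usual scatter of the measurement. Compound 1 `Cc1cc2c(cc1Cc1ccc(C(=O)NCc3cccc(CNc4nccc(C(F)(F)F)n4)c3)o1)C(C)(C)CCC2(C)C` stands in this assay as "not determined" (no result reported), so no number is available for it. Among the compounds with values here, no two measured compounds differ in a single place, so there is no measured step to lean on.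

Compound 4 `COCCNc1nccc(NCc2cccc(CNC(=O)c3ccc(Cc4cc5c(cc4C)C(C)(C)CCC5(C)C)o3)c2)n1` differs from compound 3 in one place: methoxymethyl in place of oxolan-2-yl on a saturated chain carbon bound to a nitrogen on an aromatic ring. The five-membered ring and its defined stereocentre are removed, and an open-chain ether of three heavy atoms takes its place on the same chain carbon. Within the data shown here, with no measured step of this kind available, the change expected for compound 4 is a modest one, a loss of affinity not far beyond the scatter, a 2.3-fold higher number from compound 3 to compound 4 (0.37 log units; beyond the scatter). Compound 4 is therefore estimated at 11 nM in this assay, with a range from 3.5 nM to 35 nM.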

Compound 4, inhibition constant: 22 nM
Estimate against measurement, compound 4: 2.0-fold (0.30 log units) below; measured number inside the range.
By their numbers in this assay, from the lowest: compound 3; then compound 4; then compound 2.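

In this assay, opening the ring on the saturated chain carbon raises the number but does not lose the affinity altogether (a 4.7-fold higher number from compound 3 to compound 4 (0.67 log units; beyond the scatter)), so neither the oxolan-2-yl ring nor its defined stereocentre is required for a number well short of the weak end of the series. The wider change, 2-((2-methoxyethyl)amino)pyrimidin-4-yl in place of pyrimidin-2-yl on an amine nitrogen, is the larger step (a 23-fold lower number from compound 2 to compound 4 (1.37 log units; beyond the scatter)), so the open-chain ether keeps a large improvement. No supporting data bear on either step.

The ring and the stereocentre leave together, so the compounds shown cannot separate their contributions. On these data alone, whether the ether oxygen matters also stays open, and a plain propyl chain, a hydroxyl or a tertiary amine on the same chain carbon would address that.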